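The compounds below may be only part of what the source reports. "The series", "measured", "known", "first", "only" and "open" are said of these compounds alone.

Compound 1 `CC(=O)N(C)CC#CCN(C)C`: 1.73 mg/kg
Compound 2 `COC(=O)N(C)CC#CCn1ccnc1`: 4.5 mg/kg

Both values come from a functional assay on the whole organism for agonist activity, with Mus musculus as the target; a higher number here means that more compound is needed for the effect, a lower number that less compound is needed. Compound 2 has the higher number of the two, so more of it is needed for the effect than of compound 1, and this gap lies beyond the usual scatter of repeated measurements. Going by the values given here, no two measured compounds differ in one place only, so no single structural change has a measured size yet.

Compound 3 `COC(=O)N(C)CC#CCN(C)C` has not been measured. It differs from compound 2 by dimethylamino in place of 1H-imidazol-1-yl on a saturated chain carbon bound to a triple-bonded carbon. Among the compounds with values here, the only measured compound that carries dimethylamino, compound 1 at 1.73 mg/kg, has the lower number, so a move toward a lower number is expected in this assay. This is only a rough guide, as compound 1 also differs from compound 3 elsewhere. The expected change is a 3.0-fold lower number from compound 2 to compound 3 (0.48 log units; beyond the scatter). For compound 3 the estimated value is 1.5 mg/kg, with an expected range of 0.5 mg/kg to 4.5 mg/kg.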

Compound 3, dose for half-maximal effect: 9.7 mg/kg
Compound 3: middle estimate off by 6.5-fold (0.81 log units), on the low side; the measured number lies above the stated range.
By their numbers in this assay, from the lowest: compound 1; then compound 2; then compound 3.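

In this assay, the change to dimethylamino in place of 1H-imidazol-1-yl on a saturated chain carbon bound to a triple-bonded carbon gives a 2.2-fold higher number from compound 2 to compound 3 (0.33 log units; beyond the scatter), so with methoxy on the carbonyl carbon, the compound with the open-chain amine needs more compound for the effect than the one with the ring. The second step, methoxy in place of methyl on a carbonyl carbon, gives a 5.6-fold higher number from compound 1 to compound 3 (0.75 log units; beyond the scatter), which ties the low number of compound 1 to the methyl on its carbonyl carbon and not to dimethylamino alone. No measurement available here explains either step.

As far as these compounds go, each change has so far been seen against only one background, so it remains open whether 1H-imidazol-1-yl would also give a lower number than dimethylamino with methyl on the carbonyl carbon. The compounds shown also leave open how a pyrrolidine ring in place of dimethylamino, or an ethoxy group in place of methoxy, would behave.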